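The source may report more compounds than this note shows. Statements on the series, on what has been measured and on what is new or still open speak of the compounds shown alone.

Compounds measured so far:

Compound 1, `O=c1ccc(-c2ccccc2)nn1CCCCNC(=S)Nc1cccc2ccccc12`: in a functional assay on the whole organism (stomach) with Rattus norvegicus as the target (a higher number here means that more compound is needed for the effect, a lower number that less compound is needed), compound 1 gives > 100 mg/kg, which is a limit of the assay and not a number.
Compound 2, `C/N=C(\S)NCCCCn1nc(C)ccc1=O`: in this assay compound 2 gives > 100 mg/kg, again a limit.
Compound 3, `C/N=C(/NC#N)NCCCCn1nc(C)ccc1=O`: in this assay compound 3 gives > 100 mg/kg, again a limit.

Within the data shown here, compound 3 therefore stands at the limit of > 100 mg/kg in this assay, at which 3 of the 3 values shown sit; no measured compound here has given a real number. Among the measured compounds shown here, the only single-point step, a step that the two limits leave unreadable from compound 2 to compound 3, cannot be read for size, because both its ends are limits. The new compound is compound 4, `C/N=C(/NC#N)NCCCCn1nc(-c2ccc(C)cc2)ccc1=O`, and the change from compound 3 is 4-methylphenyl in place of methyl on an aromatic carbon. For the measured compounds named here, no measured step touches this place, so nothing shows whether a larger aromatic group here matters. Compound 1 also carries a phenyl and gives only a limit, which gives no hint of gain. Compound 4 is therefore expected to remain at or near the limit, around 150 mg/kg (range 50 mg/kg to 500 mg/kg). The step this estimate means, a step that the limit leaves unreadable from compound 3 to compound 4, is expected to be none beyond the scatter.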

Compound 4, dose for half-maximal effect: > 100 mg/kg
Compound 4: only a limit was reported (the forecaster's own chance of this, stated with the estimate: 70%); the middle value lies beyond the limit too.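

Among these compounds, the change from methyl to 4-methylphenyl between compound 3 and compound 4 gives no step that can be read, because both compounds sit at the same limit: the limit of > 100 mg/kg in this assay, at which 4 of the 4 values shown sit. The compounds shown leave open which structure, if any, would give a real number in this assay.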